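Aryl variation on the shared pyrazole-acid series, third compound

The source may report more compounds than this note shows. Statements on the series, on what has been measured and on what is new or still open speak of the compounds shown alone.

Measured so far:
compound 1 `Cc1cc(Cl)cc(-c2c(C)nn(-c3nc(-c4ccc(Cl)c(Cl)c4)c(SC(C)C)s3)c2C(=O)O)c1` — 663 nM
compound 2 `COc1cc(C#N)cc(-c2c(C)nn(-c3nc(-c4ccc(Cl)c(Cl)c4)c(SC(C)C)s3)c2C(=O)O)c1` — 5200 nM

Compound 2 holds the highest of the two numbers in a functional assay on BJAB cells (Homo sapiens) for antiproliferative activity, with a stated time of 4 days; a lower number here means that less compound is needed, a higher number that more compound is needed for the effect; compound 1 gives 663 nM, and the step of a 7.8-fold higher number from compound 1 to compound 2 (0.89 log units; beyond the scatter) separates them.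

Compound 3 `Cc1nn(-c2nc(-c3ccc(Cl)c(Cl)c3)c(SC(C)C)s2)c(C(=O)O)c1-c1ccccc1Cl` is not yet measured. It differs from compound 2 in one place: 2-chlorophenyl in place of 3-cyano-5-methoxyphenyl on an aromatic carbon.

Among the compounds with values here, the only measured step that bears on this is a 7.8-fold higher number from compound 1 to compound 2 (0.89 log units; beyond the scatter), where a halogen-and-methyl-bearing aryl gave way to the 3-cyano-5-methoxyphenyl and the number rose. Compound 3 returns to a halogen-bearing aryl with no hydrogen-bond acceptors, though the pattern of substitution is not the same as in compound 1, so the reversal need not be complete. A move back toward the number of compound 1 is expected, of a size a 3.5-fold lower number from compound 2 to compound 3 (0.54 log units; beyond the scatter) in this assay, with real uncertainty about how far it goes.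

Compound 3 is estimated at 1500 nM in this assay, within 500 nM to 5000 nM.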

Compound 3, half-maximal effective concentration: 13100 nM
Compound 3: the middle estimate sits 8.7-fold (0.94 log units) below what was measured, outside the stated range (above it).
By their numbers in this assay, from the lowest: compound 1; then compound 2; then compound 3.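

In this assay, the 2-chlorophenyl has no hydrogen-bond acceptors, yet the number does not return toward that of compound 1: the change gives a 2.5-fold higher number from compound 2 to compound 3 (0.40 log units; beyond the scatter). The absence of the acceptors of the 3-cyano-5-methoxyphenyl is therefore not enough on its own to give a low number at this aromatic carbon, and a chlorine on the aryl is not enough either, as a 20-fold higher number from compound 1 to compound 3 (1.30 log units; beyond the scatter) shows, the largest step among the three compounds. The position thus responds to more than the presence of a halogen, and the order of the three aryls does not follow their hydrogen-bond acceptor count; no accompanying data offer an explanation for these steps.

As far as these compounds go, the three compounds do not separate the contributions of the chlorine placement and the methyl in the 3-chloro-5-methylphenyl, so it stays open which of these features goes with the lowest number in this assay. Also open, from the compounds shown here alone, is how an unsubstituted phenyl, or an aryl carrying an amine or a second carboxylic acid, would read at this position on the shared core.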